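A Longer Ester-Capped Chain on the Shared Core

The source may hold more compounds than are shown below. What is called first, only, known or untested is meant among the compounds shown, and "the series" means these compounds.

Three compounds measured in a functional assay on COLO 205 cells (Homo sapiens) for antiproliferative activity (on this read-out lower numbers stand for stronger inhibition of growth and higher numbers for weaker inhibition of growth), are:

compound 1 `COCCCCCCCCCCCCCCC/C=C1\CC(CO)(COC(=O)C(C)(C)C)OC1=O` gives 0.118 ug/mL
compound 2 `COCCCCCCCCCCC/C=C1\CC(CO)(COC(=O)C(C)(C)C)OC1=O` gives 0.541 ug/mL
compound 3 `CC(C)(C)C(=O)OCC1(CO)C/C(=C/CCCCCCCCCCCCCCC=O)C(=O)O1` gives 5.14 ug/mL

Compound 2 holds the middle place among these numbers, above compound 1 and below compound 3. Compound 4 `CC(C)(C)C(=O)OCCCCCCCCCCCCCCC/C=C1\CC(CO)(COC(=O)C(C)(C)C)OC1=O` has not yet been measured. It carries 4-(((tert-butyl)carbonyl)oxy)butyl in place of methoxy on a saturated chain carbon, ten or more bonds along the chain from a double-bonded chain carbon. Within the data shown here, the one measured step at this place, methoxy in place of 4-methoxybutyl, gave a 4.6-fold higher number from compound 1 to compound 2 (0.66 log units; beyond the scatter) and lies beyond the scatter. Read in reverse, that step points to a lower number for compound 4. However, compound 3, whose chain ends in a different group, shows 5.14 ug/mL and so warns that the chain end may count as well. An estimated 1.5-fold lower number from compound 2 to compound 4 (0.19 log units; within the scatter) is therefore expected, toward a lower number but not clearly beyond the scatter. The estimate for compound 4 is 0.35 ug/mL (expected range 0.09 ug/mL to 2 ug/mL).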

Compound 4, concentration for 50% growth inhibition: 0.597 ug/mL
Compound 4: the middle estimate sits 1.7-fold (0.23 log units) below what was measured; the range from low to high includes it.
By their numbers in this assay, from the lowest: compound 1; then compounds 2 and 4 (each within the scatter of the next); then compound 3.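

Compound 4 shows that chain length alone does not set the result at this position: in this assay, (tert-butyl)carbonyl in place of methyl on the oxygen gives a 5.1-fold higher number from compound 1 to compound 4 (0.70 log units; beyond the scatter) on the same chain, so the group capping the chain end counts as well. Extending the chain from methoxy to 4-(((tert-butyl)carbonyl)oxy)butyl gives a 1.1-fold higher number from compound 2 to compound 4 (0.04 log units; within the scatter) and thus no clear change, whereas the methoxy-capped pair compound 1 and compound 2 differ beyond the scatter. Nothing shown explains why the chain-end group matters here.

From the compounds shown here alone, it remains open whether a smaller acetyl ester or a free hydroxyl on that oxygen would read like compound 1 or like compound 4. Also open, going by these compounds, is how a carboxylic acid or an amine at the chain end would behave.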